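Tetrazole ketones: thiophene in place of methyl

The source may hold more compounds than are shown below. What is called first, only, known or untested is meant among the compounds shown, and "the series" means these compounds.

Compound 1 `O=C(CCCCCCc1ccccc1)c1nnn[nH]1` and compound 2 `Cn1nnc(C(=O)CCCCCCc2ccccc2)n1` share a ketone chain ending in a phenyl group. In an assay on HEK-293T cells for inhibition of diacylglycerol lipase-alpha (Homo sapiens), read by colorimetric assay (a lower number here means a stronger inhibitor, a higher number a weaker inhibitor), compound 1 gives > 10000 nM; > 10000 nM (2 entries), a limit of the assay and not a number. In this assay compound 2 gives > 10000 nM, again a limit rather than a number (the limit of > 10000 nM in this assay, at which 1 of the 2 values shown sits). Compound 2 therefore stands only at the limit, with no numbered value. Compound 3 `O=C(CCCCCCc1ccccc1)c1nnn(-c2cccs2)n1` differs by thiophen-2-yl in place of methyl on an aromatic nitrogen. Going by the values given here, no measured step covers such a change. The expected step is an at least 1.6-fold lower number from compound 2 to compound 3 (0.22 log units; that floor lies within the scatter), toward a stronger inhibitor, though uncertain. Compound 3 is expected to give 6000 nM, within 800 nM to 30000 nM.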

Compound 3, half-maximal inhibitory concentration: > 10000 nM
Compound 3: no number, only a limit; the forecaster's own chance of this, stated with the estimate: 60%; middle value at least 1.6-fold (0.22 log units) away from the limit.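

Compound 2 and compound 3 both stand only at a limit, not at a number, so no step can be read for thiophen-2-yl in place of methyl: the limit of > 10000 nM in this assay, at which 2 of the 3 values shown sit.

The compounds shown leave open whether any group on this aromatic nitrogen gives a numbered value in this assay.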